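The compounds below may be only part of what the source reports. "The series", "measured", "known", "first", "only" and "open" are said of these compounds alone.

Compound 1 `CCN1CCN(CCCn2cnc3c(N4CCN(CC)CC4)ncnc32)CC1` gives 1190 nM in an assay on HEK293 cells for antagonist activity at Toll-like receptor 9 (Homo sapiens), read by spectrophotometry; a lower number here means a stronger inhibitor, a higher number a weaker inhibitor.
Compound 2 `CCN1CCN(CCCn2cnc3c(N4CCN(C(=O)C5CCCC5)CC4)nc(NCc4ccc(OC)cc4)nc32)CC1` reaches only a limit of the assay, > 30000 nM.

Going by the values given here, compound 1 is the only compound with a number in this assay; the other value is a limit (the limit of > 30000 nM in this assay, at which 1 of the 2 values shown sits). Compound 3 `CCN1CCN(CCCn2cnc3c(N4CCN(CC)CC4)nc(N)nc32)CC1` differs from compound 1 in one place: amino in place of hydrogen on an aromatic carbon. Among the compounds with values here, no measured pair shows the effect of such a change, so the step expected in this assay is small, either within the scatter or a modest weakening. Compound 3 is expected to give 2000 nM, somewhere between 600 nM and 8000 nM, which would be a step of a 1.7-fold higher number from compound 1 to compound 3 (0.23 log units; within the scatter).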

Compound 3, half-maximal inhibitory concentration: 260 nM
Compound 3: middle estimate off by 7.7-fold (0.89 log units), on the high side; measured number below the stated range.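

In this assay an amino group on the aromatic carbon between two ring nitrogen atoms brings a 4.6-fold lower number from compound 1 to compound 3 (0.66 log units; beyond the scatter) and so shows that this position on the core of compound 1 can be changed with a gain in inhibition. A single added heavy atom is enough for this step. Nothing measured here gives a reason for it. Still open, going by these compounds, is whether a methylamino group, a dimethylamino group, a methoxy group or a chlorine atom on the same carbon would bring a similar gain.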